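This account rests on a few compounds, and the source may have more. Where it says the series, first, only, none or still open, it means among the compounds named here.

In a functional assay on UACC-62 cells (Homo sapiens) for antiproliferative activity (on this read-out higher numbers stand for weaker inhibition of growth and lower numbers for stronger inhibition of growth), three compounds that share a hexylamino group on a carbonyl carbon have been measured. Compound 1 (`CCCCCCNC(=O)c1cc(CCc2cc(O)ccc2O)ccc1O`) gives 3300 nM, and compound 3 (`CCCCCCNC(=O)c1cc(/C=C\c2cc(O)ccc2O)ccc1O`) gives 5800 nM, two numbers within the usual scatter of each other. Compound 2 (`CCCCCCNC(=O)c1cc(C#Cc2cc(OC)ccc2OC)ccc1OC`) gives 56800 nM. This is the highest number of the three and lies beyond the scatter from both others, making compound 2 the weakest growth inhibitor of the set.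

Compound 4 (`COc1ccc(OC)c(C#Cc2ccc(OC)c(C(=O)O)c2)c1`) keeps the rest of compound 2 but has hydroxy in place of hexylamino on a carbonyl carbon. Hexylcarbamoyl thus becomes carboxy. Among the compounds with values here, no measured pair shows what this change does, so any forecast is a judgement. Every measured compound carries the hexylamino group, and compound 2 is already weak at 56800 nM. A modest further weakening in this assay is therefore expected, and the result may be only a limit. The estimated change is a 2.1-fold higher number from compound 2 to compound 4 (0.32 log units; beyond the scatter), towards weaker inhibition of growth. Compound 4 is estimated at 120000 nM, with an expected range from 40000 nM to 350000 nM.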

Compound 4, concentration for 50% growth inhibition: 22600 nM
Compound 4: middle estimate off by 5.3-fold (0.73 log units), on the high side; the whole stated range lies above it.
By their numbers in this assay, from the lowest: compounds 1 and 3 (each within the scatter of the next); then compound 4; then compound 2.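

In this assay, replacing hexylamino with hydroxy on the carbonyl carbon gives a 2.5-fold lower number from compound 2 to compound 4 (0.40 log units; beyond the scatter), a modest move towards stronger inhibition of growth. Within the data shown here, this is the first measured pair for this change, and it shows that on the core of compound 2 the hexylamino group is not required for growth inhibition, since the carboxy compound inhibits growth somewhat more strongly. No measurement shown here explains this difference.

As far as these compounds go, it remains open whether the same replacement would have the same effect on the cores of compound 1 and compound 3, which carry hydroxy groups and a different link between the rings. It is also unknown how a methyl ester, or an amide with a shorter chain such as butylamino, would behave on this carbonyl carbon.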